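A few compounds are considered here, and "the series" means these few. Any claim that something is new, unique, unknown or untested is made for them only; others in the source may bear on it.

Compound 1 `CC(=O)N1N=C(c2cccc3ccccc23)CC1c1ccccc1[N+](=O)[O-]` gives 3540 nM in a functional assay on PC-3 cells (Homo sapiens) for cytotoxicity, read by sulforhodamine B assay, with a stated time of 48 h (on this read-out higher numbers stand for weaker inhibition and lower numbers for stronger inhibition), the higher of the two numbers recorded so far; compound 2 `COc1ccc(C2CC(c3cccc4ccccc34)=NN2C(C)=O)c(OC)c1OC` gives 1220 nM in this assay, a gap beyond the usual scatter. Compound 3 `COc1cc(C2CC(c3cccc4ccccc34)=NN2C(C)=O)ccc1O` has not yet been measured. It differs from compound 1 by 4-hydroxy-3-methoxyphenyl in place of 2-nitrophenyl on a saturated ring carbon. Among the measured compounds shown here, no measured pair isolates this change, so only the two known values offer guidance, and compound 2 at 1220 nM hints that a phenyl ring bearing oxygen groups tends toward lower numbers. Compound 3 is therefore expected near 2000 nM (range 700 nM to 6000 nM), a step of a 1.8-fold lower number from compound 1 to compound 3 (0.25 log units; within the scatter) that may well fall within the scatter.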

Compound 3, half-maximal inhibitory concentration: 2130 nM
The estimate for compound 3 lay 1.1-fold (0.03 log units) below the measured number; the range from low to high includes it.
By their numbers in this assay, from the lowest: compounds 2, 3 and 1 (each within the scatter of the next, the first and the last beyond it).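

In this assay, 4-hydroxy-3-methoxyphenyl in place of 2-nitrophenyl on the saturated ring carbon gives a 1.7-fold lower number from compound 1 to compound 3 (0.22 log units; within the scatter), so this exchange cannot be told from the scatter. At this position, then, two differently substituted phenyl rings read alike, even though one carries a nitro group and the other a hydroxy and a methoxy group. No measurement at hand bears on why this is so. Going by these compounds, it remains open whether the hydroxy or the methoxy group of compound 3 counts on its own. On these data alone, it is also open whether an amine or a carboxylic acid on this phenyl ring would move the number beyond the scatter.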